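This account rests on a few compounds, and the source may have more. Where it says the series, first, only, none or still open, it means among the compounds named here.

Measured compounds:
compound 1 `COc1ccc(-c2cc(C(=O)N3CCC4(CC3)CC(=O)c3nn(C(C)(C)C)cc3O4)c3ccccc3n2)cc1OC` — 2030 nM
compound 2 `CN1CCN(c2cc(C(=O)N3CCC4(CC3)CC(=O)c3nn(C(C)(C)C)cc3O4)c3ccccc3n2)CC1` — > 10000 nM

Going by the values given here, in a functional assay on A549 cells (Homo sapiens) for inhibition, read by MTT assay, with a stated time of 72 h (a lower number here means a stronger inhibitor, a higher number a weaker inhibitor), compound 1 gives 2030 nM, the only plain number in hand. Compound 2 reaches only the assay limit of > 10000 nM (the limit of > 10000 nM in this assay, at which 1 of the 2 values shown sits). Among the compounds with values here, the single measured step, an at least 4.9-fold higher number from compound 1 to compound 2 (0.69 log units; beyond the scatter), lies beyond the scatter. Compound 3 `CC(C)Oc1cc(C(=O)N2CCC3(CC2)CC(=O)c2nn(C(C)(C)C)cc2O3)c2ccccc2n1` carries the change isopropoxy in place of 3,4-dimethoxyphenyl on an aromatic carbon relative to compound 1. That change likewise removes the 3,4-dimethoxyphenyl from its aromatic carbon, so the measured step is the nearest guide and points toward a weaker inhibitor. Compound 3 is therefore expected near 6000 nM, within 2000 nM to 15000 nM. The estimated step of a 3.0-fold higher number from compound 1 to compound 3 (0.47 log units; beyond the scatter) is expected to lie beyond the scatter.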

Compound 3, half-maximal inhibitory concentration: > 10000 nM
Compound 3: only a limit was reported; the forecaster's own chance of this, stated with the estimate: 40%; middle value at least 1.6-fold (0.22 log units) away from the limit.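

In this assay, isopropoxy in place of 3,4-dimethoxyphenyl gives an at least 4.9-fold higher number from compound 1 to compound 3 (0.69 log units; beyond the scatter), and the value of compound 3 is a limit, not a number. The step therefore holds for an entering group with no ring as well as for 4-methylpiperazin-1-yl, and only compound 1 keeps a plain number. The step between compound 2 and compound 3 cannot be read, and the two cannot be ordered: the limit of > 10000 nM in this assay, at which 2 of the 3 values shown sit.

On these data alone, whether phenyl or 4-methoxyphenyl at this position would also give a plain number stays open. As far as these compounds go, how far compound 2 and compound 3 lie past the limit also stays open.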